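Extending the Linker to the Sulfamoylamino Group in Compound 2

The source may hold more compounds than are shown below. What is called first, only, known or untested is meant among the compounds shown, and "the series" means these compounds.

Compound 2 `COC(=O)c1ccc(-c2cc(N3CCC(CNS(N)(=O)=O)CC3)ncn2)cc1` was tested in a functional assay on MCF7 cells (Homo sapiens) for antiproliferative activity, read by sulforhodamine B assay, with a stated time of 48 h (on this read-out lower numbers stand for stronger inhibition of growth and higher numbers for weaker inhibition of growth), where compound 2 gives 17700 nM. Among the three measured compounds this is the second highest number: compound 1 `COc1ccc(-c2cc(N3CCC(CNS(N)(=O)=O)CC3)ncn2)cc1` gives 35300 nM, and a 2.0-fold lower number from compound 1 to compound 2 (0.30 log units; within the scatter) stays within the scatter, whereas compound 3 `CCOC(=O)c1ccc(-c2cc(N3CCC(CNS(N)(=O)=O)CC3)ncn2)cc1` gives 4100 nM, with a 4.3-fold lower number from compound 2 to compound 3 (0.64 log units; beyond the scatter) and an 8.6-fold lower number from compound 1 to compound 3 (0.93 log units; beyond the scatter) both lying beyond it. Compound 4 `COC(=O)c1ccc(-c2cc(N3CCC(CCNS(N)(=O)=O)CC3)ncn2)cc1` differs from compound 2 by (sulfamoylamino)methyl in place of sulfamoylamino on a saturated chain carbon bound to a saturated ring carbon. Going by the values given here, none of the measured steps touches this part of the molecule; all three alter the group on the aromatic ring instead, so they give no direct guide. No step beyond the scatter is therefore expected, a 1.1-fold lower number from compound 2 to compound 4 (0.04 log units; within the scatter). Compound 4 is estimated at 16000 nM, with a range from 5000 nM to 45000 nM.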

Compound 4, concentration for 50% growth inhibition: 17600 nM
Compound 4: the middle estimate sits 1.1-fold (0.04 log units) below what was measured; the range from low to high includes it.
By their numbers in this assay, from the lowest: compound 3; then compounds 4, 2 and 1 (each within the scatter of the next).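

In this assay, the step to (sulfamoylamino)methyl on this saturated chain carbon gives a 1.0-fold lower number from compound 2 to compound 4 (0.00 log units; within the scatter), so the two compounds cannot be told apart. Going by these compounds alone, the earlier compounds varied only the group on the aromatic ring; this is the first sign that, with methoxycarbonyl held constant, the chain carrying the sulfamoylamino group can be extended by this much without a readable loss of growth inhibition.

Still open, going by these compounds, is whether a longer chain would behave the same way, or whether an amine or a carboxylic acid could replace the sulfamoylamino group. It is also unclear whether this tolerance holds with the ethoxycarbonyl group of compound 3. No supporting data bear on this result.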